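Swapping bromo for methyl on a hydroxylated stilbene

The source may hold more compounds than are shown below. What is called first, only, known or untested is meant among the compounds shown, and "the series" means these compounds.

Measured compounds:
Compound 1 `Oc1ccccc1/C=C/c1ccc(Br)cc1`: 7400 nM
Compound 2 `COc1cc(/C=C/c2ccc(OC)cc2O)cc(OC)c1`: 8400 nM
Compound 3 `COc1ccc(/C=C/c2cccc(OC)c2O)c(OC)c1`: 5100 nM

Three stilbenes carrying a free phenol have been tested in a functional assay on MDA-MB-468 cells (Homo sapiens) for antiproliferative activity, read by MTT assay; a lower number here means a stronger inhibitor, a higher number a weaker inhibitor. Compound 1 gives 7400 nM, compound 2 gives 8400 nM, and compound 3 gives 5100 nM. Compound 1 stands within the usual scatter of both compound 2 and compound 3, so none of the three can be singled out as more or less active than another on these numbers.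

Compound 4 `Cc1ccc(/C=C/c2ccccc2O)cc1` differs from compound 1 in one place: methyl in place of bromo on an aromatic carbon. The change is small in size, both groups counting one heavy atom, and it sits on an aromatic carbon of a six-membered aromatic ring of carbon only, para to a group of 9 heavy atoms. Among the compounds with values here, no measured pair shows what this swap does here, so the expectation rests on compound 1 alone. A step of a 1.2-fold higher number from compound 1 to compound 4 (0.09 log units; within the scatter) is expected, that is, nothing clearly beyond the scatter. Compound 4 is therefore estimated at 9000 nM, with a likely range from 3500 nM to 23000 nM.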

Compound 4, half-maximal inhibitory concentration: 21900 nM
Beside the measured number, compound 4's estimate is 2.4-fold (0.39 log units) below it; the range from low to high includes it.
By their numbers in this assay, from the lowest: compounds 3, 1 and 2 (each within the scatter of the next); then compound 4.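

In this assay the group on this aromatic carbon proves to matter: methyl in place of bromo brings a 3.0-fold higher number from compound 1 to compound 4 (0.47 log units; beyond the scatter) and gives the first modest difference in this set that stands beyond the scatter. Within the data shown here, the three earlier compounds could not show this, as none of them differs from another in only one place and their numbers all lie within the scatter of one another. Nothing at hand says what lies behind the step.

Still open, from the compounds shown here alone, is how other groups on this carbon, such as an amine, a nitrile or a carboxylic acid, would compare with bromo and methyl. Among these compounds, also open is whether the same swap would shift the number similarly on a stilbene carrying other groups, as this is the only such pair here.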